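Liver-cell toxicity of a quinazoline series: extending the ether

The source may report more compounds than this note shows. Statements on the series, on what has been measured and on what is new or still open speak of the compounds shown alone.

Compound 1, `CS(=O)(=O)c1cccc(-c2ccc3ncnc(Nc4ccc(OCc5cccc(F)c5)c(Cl)c4)c3c2)c1`, in an ADME assay on HepG2 cells (Homo sapiens) for cytotoxicity, read by MTT assay, with a stated time of 48 h (on this read-out lower numbers stand for stronger inhibition and higher numbers for weaker inhibition), gives > 15000 nM, which is a limit of the assay rather than a number.
Compound 2, `O=S(=O)(c1ccc(-c2ccc3ncnc(Nc4ccccc4)c3c2)cc1)N1CCOCC1`, in this assay gives > 3000 nM, again a limit.
Compound 3, `COc1ccc(Nc2ncnc3ccc(-c4ccc(S(=O)(=O)N5CCOCC5)cc4)cc23)cc1Cl`, in this assay gives > 15000 nM, also a limit.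

Compound 3 therefore stands at the limit of > 15000 nM in this assay, at which 2 of the 3 values shown sit, and compound 1 sits at that same limit. Compound 2 sits at the limit of > 3000 nM in this assay, at which 1 of the 3 values shown sits. Within the data shown here, the one change among measured compounds that touches a single place, a step that the two limits leave unreadable from compound 2 to compound 3, cannot be read, as both ends are limits.

Compound 4, `O=S(=O)(c1ccc(-c2ccc3ncnc(Nc4ccc(OCc5cc(F)cc(F)c5F)c(Cl)c4)c3c2)cc1)N1CCOCC1`, differs from compound 3 by 2,3,5-trifluorophenyl in place of hydrogen on a saturated chain carbon bound to an oxygen on an aromatic ring. Among the measured compounds shown here, no measured step bears on this change: the only single-place step between measured compounds is the unreadable one just named, and compound 1, which carries a related benzyl ether, gives only a limit. Nothing here points to a readable move in either direction in this assay beyond the usual scatter.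

Compound 4 is therefore expected to give about 20000 nM in this assay, within 8000 nM to 60000 nM, most likely reported again as a limit. The expected step that the limit leaves unreadable from compound 3 to compound 4 is essentially none.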

Compound 4, half-maximal inhibitory concentration: > 3000 nM
Compound 4: no number, only a limit; the forecaster's own chance of this, stated with the estimate: 80%; the middle value lies beyond the limit too.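

Compound 3 and compound 4 both give only limits in this assay, so the step between them cannot be read. The compounds shown leave open the concentration at which any of them would actually harm these liver cells, and whether going from methoxy to (2,3,5-trifluorobenzyl)oxy changes that concentration at all.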